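This account rests on a few compounds, and the source may have more. Where it says the series, first, only, none or still open, it means among the compounds named here.

In an ADME assay on HEp-2 cells (Homo sapiens) for cytotoxicity, with a stated time of 4 days (on this read-out lower numbers stand for higher toxicity in this test and higher numbers for lower toxicity in this test), compound 3 `CC(C)(O)CCn1c(Cn2nc(S(C)(=O)=O)c3ccncc32)nc2cc(Cl)ccc21` reaches only a limit, > 100000 nM. Compound 2 `CS(=O)(=O)c1nn(Cc2nc3cc(Cl)ccc3n2CCO)c2cnccc12` likewise stops at a limit in this assay, > 100000 nM. Compound 1 `CS(=O)(=O)CCCn1c(Cn2cc(S(=O)(=O)C3CC3)c3ccccc32)nc2cc(Cl)ccc21` also gives no number in this assay but a limit, > 100000 nM. All three readings sit together at the limit of > 100000 nM in this assay, at which 3 of the 3 values shown sit, so none of the three compounds can be set above or below another, and nothing separates them.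

Among the measured compounds shown here, the one measured step that matches the kind of change considered here is a step that the two limits leave unreadable from compound 2 to compound 3, a step between two limits whose size is therefore not readable. Compound 4 `CS(=O)(=O)c1nn(Cc2nc3cc(Cl)ccc3n2CCC(O)C(F)(F)F)c2cnccc12` differs from compound 3 by 2,2,2-trifluoro-1-hydroxyethyl in place of 1-hydroxy-1-methylethyl on a saturated chain carbon, two bonds along the chain from an aromatic nitrogen. For the measured compounds named here, because a step that the two limits leave unreadable from compound 2 to compound 3 cannot be read, the nearby evidence gives no sign of any step in this assay beyond the scatter, in either direction.

Compound 4 is therefore expected to remain at the same limit, with an estimate of 150000 nM in this assay, in a range from 60000 nM to 400000 nM. The expected step that the limit leaves unreadable from compound 3 to compound 4 is estimated as none beyond the scatter.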

Compound 4, half-maximal cytotoxic concentration: > 100000 nM
Compound 4 ended at the assay's limit (the forecaster's own chance of this, stated with the estimate: 85%); the middle value is on the limit's open side.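

Compound 4 gives only a limit, as do compound 2 and compound 3, so no step among these compounds can be read: the limit of > 100000 nM in this assay, at which 4 of the 4 values shown sit.

What the compounds shown leave open is whether these chain groups differ from one another at all in this assay.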